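Bromo replaces hydroxycyclohexylamino on the benzylic ring of compound 2

A few compounds are considered here, and "the series" means these few. Any claim that something is new, unique, unknown or untested is made for them only; others in the source may bear on it.

Compound 2 `OC1CCCC(Nc2cccc(CNc3cc(C(F)(F)F)cc4[nH]ncc34)c2)C1` stands lowest of the two measured compounds: in an assay for inhibition of Indoleamine 2,3-dioxygenase 1 (Homo sapiens), with stated times of 10 min and 60 min, tested at 100 uM (a higher number here means a stronger effect of the compound at the concentration tested, a lower number a weaker effect), compound 2 gives 2%, while compound 1 `FC(F)(F)c1cc(NCC2CNC2)c2cn[nH]c2c1` gives 22%, a gap beyond the scatter. Compound 3 `FC(F)(F)c1cc(NCc2cccc(Br)c2)c2cn[nH]c2c1` differs from compound 2 by bromo in place of (3-hydroxycyclohexyl)amino on an aromatic carbon. Among the compounds with values here, no measured pair shows this change, so the size of the step is open. A modest upward step is expected, from compound 2 to compound 3 of a number 10 percentage points higher from compound 2 to compound 3 (within the scatter), since compound 1 with its smaller side group reaches 22%. For compound 3 the estimate is 12%, within -5% to 30%.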

Compound 3, a percentage reported as inhibition, at one concentration (the size of the read-out at that concentration, not a potency): 51%
Beside the measured number, compound 3's estimate is 39 percentage points below it; measured number outside the range, above it.
By their numbers in this assay, from the lowest: compound 2; then compound 1; then compound 3.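

In this assay, the aromatic carbon holding (3-hydroxycyclohexyl)amino in compound 2 responds strongly to the change to bromo (a number 49 percentage points higher from compound 2 to compound 3 (beyond the scatter)), so the group at this position sets much of the read-out. The 3-bromophenyl group also reads higher than the azetidin-3-yl group on the saturated chain carbon (a number 29 percentage points higher from compound 1 to compound 3 (beyond the scatter)). Nothing at hand accounts for either step.

As far as these compounds go, whether the rise comes from bromo itself or from the loss of (3-hydroxycyclohexyl)amino stays open. Chloro, methoxy or plain hydrogen on this carbon would be needed to separate the two.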